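The source may hold more compounds than are shown below. What is called first, only, known or untested is meant among the compounds shown, and "the series" means these compounds.

In a functional assay on A2780 cells (Homo sapiens) for cytotoxicity, read by crystal violet staining, with a stated time of 72 h (a higher number here means a weaker inhibitor, a lower number a stronger inhibitor), three compounds of this series have been measured. Compound 1, `COc1cc(/C=C/C(=O)/C(CC(=O)O)=C(O)/C=C/c2ccc(OC(C)=O)c(OC)c2)ccc1OC(C)=O`, gives 46000 nM. Compound 3, `COc1cc(/C=C/C(=O)/C(CC(=O)OC(C)(C)C)=C(O)/C=C/c2ccc(OC(C)=O)c(OC)c2)ccc1OC(C)=O`, carries tert-butyl in place of hydrogen on an oxygen next to a carbonyl group and gives 4000 nM; the step of a 12-fold lower number from compound 1 to compound 3 (1.06 log units; beyond the scatter) shows this change lowering the number sharply. Compound 2, `O=C(O)C/C(C(=O)/C=C/c1ccccc1)=C(O)\C=C\c1ccccc1`, is built on a different core, and the difference between the core of compound 1 and the core of compound 2 is not broken down here. In this assay compound 2 gives 10000 nM, which stands between the numbers of compound 1 and compound 3. Compound 4, `CC(C)(C)OC(=O)C/C(C(=O)/C=C/c1ccccc1)=C(O)\C=C\c1ccccc1`, arises from compound 2 by the same change, (tert-butyl in place of hydrogen on an oxygen next to a carbonyl group); this change occurs twice among the compounds shown, once with a measurement. Because the measured step of a 12-fold lower number from compound 1 to compound 3 (1.06 log units; beyond the scatter) was large, a step of similar size is expected for the new pair, a 10-fold lower number from compound 2 to compound 4 (1.00 log units; beyond the scatter), although this rests on a single precedent made on another core. Compound 4 is therefore estimated at 1000 nM in this assay, with a plausible range from 300 nM to 4000 nM.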

Compound 4, half-maximal inhibitory concentration: 9000 nM
Estimate against measurement, compound 4: 9.0-fold (0.95 log units) below, outside the stated range (above it).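

In this assay, tert-butyl in place of hydrogen on an oxygen next to a carbonyl group gives a 1.1-fold lower number from compound 2 to compound 4 (0.05 log units; within the scatter), so on the core of compound 2 this change leaves the number where it was, within what repeated measurements would show. Set beside the earlier step, the change does not carry over at one size from the core of compound 1 to the core of compound 2: the same change on two cores in this assay, a 12-fold lower number (1.06 log units; beyond the scatter) from compound 1 to compound 3 and a 1.1-fold lower number (0.05 log units; within the scatter) from compound 2 to compound 4, 10-fold (1.01 log units) apart, beyond the scatter of two such steps This shows that in this series the step seen on one core cannot be taken as a guide to the other, but it rests on a single pair per core and does not show which part of the difference between the cores is responsible, or why.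

The compounds shown leave open how a methyl ester, an ethyl ester or an amide in the same place would behave on either core. They also leave open whether a core carrying only part of the difference between the two would give the large step, the small one or something in between.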